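Swapping Trifluoromethyl for Nitro on a Thiourea Series

The source may hold more compounds than are shown below. What is called first, only, known or untested is meant among the compounds shown, and "the series" means these compounds.

Three thioureas have been measured so far. Compound 1 `CC1(C)CCOc2ccc(NC(=S)Nc3ccc(C(F)(F)F)cc3)cc21` gives 5500 nM in a functional assay on A2780 cells (Homo sapiens) for inhibition, with a stated time of 72 h; on this read-out lower numbers stand for stronger inhibition and higher numbers for weaker inhibition. Compound 3 `CCC1(CC)CC(C)(C)Oc2ccc(NC(=S)Nc3ccc(C(F)(F)F)cc3)cc21` is built on a different core; the difference between the two cores is not broken down here. In this assay compound 3 gives 4700 nM. Compound 2 `CCC1(CC)CC(C)(C)Oc2ccc(NC(=S)Nc3ccc([N+](=O)[O-])cc3)cc21` shares the core of compound 3 and differs from it in one place: nitro in place of trifluoromethyl on an aromatic carbon. In this assay compound 2 gives 3690 nM. The step of a 1.3-fold lower number from compound 3 to compound 2 (0.11 log units; within the scatter) shows that the two numbers cannot be told apart. Compound 1 and compound 3 also give numbers within the scatter of each other, as do compound 1 and compound 2, so none of the three can be called stronger or weaker than the others.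

Compound 4 `CC1(C)CCOc2ccc(NC(=S)Nc3ccc([N+](=O)[O-])cc3)cc21` has not yet been measured. It stands to compound 1 as compound 2 stands to compound 3: nitro in place of trifluoromethyl on an aromatic carbon. The place of the exchange is the same in both cases, so this is the same change carried onto the core of compound 1. For compound 4 the expected step is a 1.3-fold lower number from compound 1 to compound 4 (0.11 log units; within the scatter). Among the compounds with values here, this expectation rests on compound 2, whose step a 1.3-fold lower number from compound 3 to compound 2 (0.11 log units; within the scatter) is the only measurement of this exchange available here, and it is therefore uncertain. Compound 4 is expected to give about 4300 nM in this assay, most likely between 2000 nM and 9500 nM.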

Compound 4, half-maximal inhibitory concentration: 6400 nM
The estimate for compound 4 lay 1.5-fold (0.17 log units) below the measured number; measured number inside the range.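

Carried onto the other core, nitro in place of trifluoromethyl gives a 1.2-fold higher number from compound 1 to compound 4 (0.07 log units; within the scatter), so the two numbers cannot be told apart in this assay. Set beside the earlier step, the exchange looks the same on both cores as far as these data can tell, with neither step large enough to read and no real difference between them: the same change on two cores in this assay, a 1.3-fold lower number (0.11 log units; within the scatter) from compound 3 to compound 2 and a 1.2-fold higher number (0.07 log units; within the scatter) from compound 1 to compound 4, 1.5-fold (0.17 log units) apart, within the scatter of two such steps

This shows that swapping these two groups left no readable mark on either core, and the opposite directions of the two small steps carry no meaning. It does not show that the groups are truly interchangeable, and with no clear effect on either core, it cannot show whether a real effect would carry from one core to the other; two cores are also a narrow basis for any rule across the series.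

As far as these compounds go, only trifluoromethyl and nitro appear at this place on the aromatic ring, so it remains open whether a group such as a nitrile, an amine or a carboxylic acid would give a step large enough to read. Within the data shown here, what each part of the difference between the two cores contributes also remains open, as no pair here separates those parts.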